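Dropping the methyl from compound 1's benzyl group

The source may report more compounds than this note shows. Statements on the series, on what has been measured and on what is new or still open speak of the compounds shown alone.

Measured compounds:
compound 1 `C#CCN(CCCOc1ccc2ccc(=O)oc2c1)Cc1ccc(C)cc1`: 7380 nM
compound 2 `C#CCN(CCCCOc1ccc2ccc(=O)oc2c1)Cc1ccc(C(C)C)cc1`: 3500 nM
compound 3 `C#CCN(CCCCOc1ccc2ccc(=O)oc2c1)Cc1ccc(C)cc1`: 1680 nM

Three compounds share a core and were tested in an assay on isolated protein for inhibition of Amine oxidase [flavin-containing] B (Homo sapiens), read by fluorescence and Amplex Red, with stated times of 15 min and 20 min; a lower number here means a stronger inhibitor, a higher number a weaker inhibitor. Compound 1 gives the highest number of the three; compound 2 sits nearest to it with a lower number, and compound 3 is furthest, with the lowest number of the set. Compound 4 `C#CCN(CCCOc1ccc2ccc(=O)oc2c1)Cc1ccccc1` has not yet been measured in this assay. It differs from compound 1 in one place: hydrogen in place of methyl on an aromatic carbon, a hydrogen in place of the methyl on the aromatic carbon para to a large group. Going by the values given here, the only measured step that bears on it is a 2.1-fold lower number from compound 2 to compound 3 (0.32 log units; beyond the scatter), where a smaller group on that same aromatic carbon went with a lower number. That change is not the same as removing the group entirely, so the guidance is indirect. For compound 4, a small step of a 1.5-fold lower number from compound 1 to compound 4 (0.17 log units; within the scatter) is therefore expected, toward a lower number and close to the scatter. Compound 4 is estimated at 5000 nM, with a range from 2000 nM to 12000 nM.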

Compound 4, half-maximal inhibitory concentration: 3740 nM
For compound 4 the middle estimate is 1.3-fold (0.13 log units) above the measured one; the measured number falls inside the stated range.
By their numbers in this assay, from the lowest: compound 3; then compounds 2, 4 and 1 (each within the scatter of the next, the first and the last beyond it).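

In this assay, taking the methyl off the aromatic carbon para to a large group gives a 2.0-fold lower number from compound 1 to compound 4 (0.30 log units; within the scatter), so the 4-methylbenzyl and benzyl compounds cannot be told apart at this position. Going by these compounds alone, the earlier step at this carbon compared only two alkyl groups, on the longer chain of compound 2 and compound 3; this one is the first to show the carbon with only hydrogen on it, and it does so on the shorter chain of compound 1. Nothing shown gives a reason for this result.

Still open, from the compounds shown here alone, is how a chlorine atom or a methoxy group on that same carbon would read in this assay. Also open, going by these compounds, is whether the plain benzyl group would read the same on the longer chain of compound 3.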